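From hydroxyamino to methoxy on a carbonyl carbon

The compounds below may be only part of what the source reports. "The series", "measured", "known", "first", "only" and "open" are said of these compounds alone.

Compound 1 `COc1cc(NC(C)CCCNC(=O)NCCO)c2ncccc2c1`: > 100000 nM (a limit)
Compound 2 `COc1cc(NC(C)CCCNC(=O)NC(CO)(CO)CO)c2ncccc2c1`: > 100000 nM (a limit)
Compound 3 `COc1cc(NC(C)CCCNC(=O)NO)c2ncccc2c1`: 57000 nM

Within the data shown here, in a functional assay on HCT-116 cells (Homo sapiens) (a higher number here means a weaker inhibitor, a lower number a stronger inhibitor), compound 3 gives 57000 nM, the only real number among the three. Compound 4 `COC(=O)NCCCC(C)Nc1cc(OC)cc2cccnc12` differs from it by methoxy in place of hydroxyamino on a carbonyl carbon. Two measured steps change the group on the amide-type nitrogen of that same stretch: an at least 1.7-fold lower number from compound 1 to compound 3 (0.24 log units; that floor lies within the scatter) and an at least 1.7-fold lower number from compound 2 to compound 3 (0.24 log units; that floor lies within the scatter). Both are only floors. A small step towards a higher number is expected, since compound 3 sits at 57000 nM and neither other group gave a real number. The result may well be only a limit. The estimated change is a 1.6-fold higher number from compound 3 to compound 4 (0.20 log units; within the scatter). For compound 4 the expected value is 90000 nM, with an estimated range of 40000 nM to 200000 nM.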

Compound 4, half-maximal inhibitory concentration: > 100000 nM
Compound 4 gave a limit, no number; the forecaster's own chance of this, stated with the estimate: 55%; middle value at least 1.1-fold (0.04 log units) from the limit.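

Swapping hydroxyamino for methoxy on the carbonyl carbon gives an at least 1.7-fold higher number from compound 3 to compound 4 (0.24 log units; that floor lies within the scatter), so the true size of this step stays unknown. Compound 4 ends at a limit, and the steps to it from compound 1 and compound 2 cannot be read. Among these four compounds, only hydroxyamino, in compound 3, gives a real number, while the others share one ceiling: the limit of > 100000 nM in this assay, at which 3 of the 4 values shown sit.

As far as these compounds go, whether amino or methylamino on this carbonyl carbon would also give a real number remains open. So does whether any group here could bring the number far below that of compound 3, 57000 nM.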